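The compounds below may be only part of what the source reports. "The series", "measured", "known", "first", "only" and "open" are said of these compounds alone.

The compounds measured so far:
compound 1, `O=C(O)CC/C=C\CO[C@H]1C(OCc2ccc(-c3ccccc3)cc2)CC[C@@H]1N1CCCCC1`, 794 nM; 63.1 nM (2 entries)
compound 2, `O=C(O)CC/C=C\CO[C@H]1C(OCc2ccc(-c3ccccc3CCO)cc2)CC[C@@H]1N1CCCCCC1`, 31.6 nM
compound 3, `O=C(O)CC/C=C\CO[C@H]1[C@@H](OCc2ccc(-c3ccccc3)cc2)CC[C@@H]1N1CCCCCC1`, 39.8 nM

In a functional assay for antagonist activity at thromboxane A2 receptor (Rattus norvegicus) (a lower number here means tighter binding, a higher number weaker binding), compound 2 gives 31.6 nM, the lowest of the two single numbers at hand. Its nearest neighbour is compound 3, which in this assay gives 39.8 nM; the gap between these two lies within the scatter, so neither can be set above the other. Compound 1 stands apart in that it carries no single number: the several entries of compound 1 in this assay, 794 nM; 63.1 nM (2 entries), and the two entries differ by more than the scatter allows, so compound 1 is kept out of the comparison. None of the pairs among these three differs in only one place, so no measured step is available to guide the next one.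

Compound 4, `O=C(O)CC/C=C\CO[C@H]1C(OCc2ccc(-c3ccc(CO)cc3)cc2)CC[C@@H]1N1CCCCCC1`, has not yet been measured in this assay. It differs from compound 2 in one place: 4-(hydroxymethyl)phenyl in place of 2-(2-hydroxyethyl)phenyl on an aromatic carbon. The hydroxyl is kept, the phenyl is kept, and only the length of the arm and where it sits on the ring change. For the measured compounds named here, with no measured step of this kind to lean on, the step expected is a 1.3-fold higher number from compound 2 to compound 4 (0.10 log units; within the scatter), amounting to no change beyond the scatter, with the range widened to allow either direction. Compound 4 is therefore estimated at 40 nM in this assay, expected to fall between 10 nM and 160 nM.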

Compound 4, dissociation constant: 20 nM
Compound 4: the middle estimate sits 2.0-fold (0.30 log units) above what was measured; low and high end bracket the measured number.
By their numbers in this assay, from the lowest: compounds 4, 2 and 3 (each within the scatter of the next).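

In this assay the first step read at this position is a 1.6-fold lower number from compound 2 to compound 4 (0.20 log units; within the scatter) and it comes with 4-(hydroxymethyl)phenyl in place of 2-(2-hydroxyethyl)phenyl. The earlier compounds shown here offered no step of any kind, whereas this pair shows that the arm carrying the hydroxyl can be shortened and can change its place on the ring, now para to a large group, without moving the number beyond the scatter, so neither form of the arm can be set above the other. Nothing in the evidence at hand bears on why this exchange leaves the number within the scatter.

Arm length and ring place change together in this single step, so the share of each stays unresolved, and 4-(2-hydroxyethyl)phenyl or 2-(hydroxymethyl)phenyl would be needed to part them. From the compounds shown here alone, it also remains open whether the hydroxyl itself matters, since a step from either arm to a plain methyl, a methoxymethyl, an aminomethyl or a carboxylic acid on the same ring would be required to tell.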